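Replacing an aromatic group in a series at its limit

The source may report more compounds than this note shows. Statements on the series, on what has been measured and on what is new or still open speak of the compounds shown alone.

In an ADME assay on Karpas-1106P cells (Homo sapiens) for cytotoxicity (on this read-out lower numbers stand for an effect already at smaller amounts and higher numbers for an effect only at larger amounts of compound), compound 1 (`Cc1ccc(S(=O)(=O)N[C@@H](CC(=O)NC(C)(C)C)C(=O)NCCNC(=O)c2c(O)cccc2F)cc1`) gives > 11100 nM and this is a limit of the assay, not a number. Compound 2 (`Cc1ccc(S(=O)(=O)N[C@@H](CC(=O)NC(C)(C)C)C(=O)NCCNC(=O)c2ccccc2F)cc1`) gives > 11100 nM and this too is a limit. Compound 3 (`Cc1ccc(S(=O)(=O)N[C@@H](CC(=O)NC(C)(C)C)C(=O)NCCNC(=O)c2cc(C)ccc2F)cc1`) gives > 11100 nM which is again a limit. Going by the values given here, the series so far shows the limit of > 11100 nM in this assay, at which 3 of the 3 values shown sit, and compound 3 therefore has no number of its own.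

The next step leads to compound 4 (`Cc1ccc(S(=O)(=O)N[C@@H](CC(=O)NC(C)(C)C)C(=O)NCCNC(=O)c2ccc(F)c(F)c2)cc1`) and puts 3,4-difluorophenyl in place of 2-fluoro-5-methylphenyl on a carbonyl carbon, as counted in 3,4-difluorophenyl in place of 2-fluoro-5-methylphenyl on a carbonyl carbon while the shared core stays the same. Three measured changes to this same aromatic group bear on it. They are a step that the two limits leave unreadable from compound 1 to compound 2 and a step that the two limits leave unreadable from compound 2 to compound 3 and a step that the two limits leave unreadable from compound 1 to compound 3 and none of them has a readable size. None of the three compounds goes against the limit, so no step beyond the scatter is expected in either direction. The expected change is a step that the limit leaves unreadable from compound 3 to compound 4 and it may well stay unreadable. For compound 4 the estimated value is 16000 nM with an expected range from 8000 nM to 30000 nM and the assay will most likely report only a limit.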

Compound 4, half-maximal effective concentration: > 11100 nM
Compound 4 ended at the assay's limit; the forecaster's own chance of this, stated with the estimate: 85%; the middle value lies beyond the limit too.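

In this assay compound 4 gives > 11100 nM, again a limit and not a number. The steps to compound 4 from compound 1, compound 2 and compound 3 therefore cannot be read, and the series stays where it was: the limit of > 11100 nM in this assay, at which 4 of the 4 values shown sit. As far as these compounds go, whether these aromatic groups differ at all in this read-out remains open.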